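A Larger Group on the Oxygen of Compound 3

The source may hold more compounds than are shown below. What is called first, only, known or untested is meant among the compounds shown, and "the series" means these compounds.

In a physicochemical assay for solubility, read by nephelometry, in phosphate buffer, measured as kinetic solubility, with a stated time of 30 min, at pH 6.5 (a lower number here means a less soluble compound, a higher number a more soluble compound), compound 3 (`O=C(O)COc1ccc([C@H]2CC[C@]3(CC2)OOC2(O3)C3CC4CC(C3)CC2C4)cc1`) gives < 1.6 ug/mL as a limit and not a number. Compound 1 (`O=C(O)COc1ccc([C@H]2CC[C@]3(CC2)OOC2(O3)C3CC4CC2CC(C3)C4O)cc1`), with hydroxy on a saturated ring carbon, gives < 1.6 ug/mL as a limit too. Compound 2 (`O=C(O)COc1ccc([C@H]2CC[C@]3(CC2)OOC2(O3)C3CC4CC(C3)CC2C4)cc1Cl`), with chloro on an aromatic carbon, gives < 3.1 ug/mL as a limit too. The three readings thus gather at two limits (the limit of < 1.6 ug/mL in this assay, at which 2 of the 3 values shown sit) and (the limit of < 3.1 ug/mL in this assay, at which 1 of the 3 values shown sits) with no true number among them.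

Compound 4 (`CC(C)(Oc1ccc([C@H]2CC[C@]3(CC2)OOC2(O3)C3CC4CC(C3)CC2C4)cc1)C(=O)O`) differs from compound 3 in one place: 1-carboxy-1-methylethyl in place of carboxymethyl on an oxygen on an aromatic ring.

The two measured steps (a step that the two limits leave unreadable from compound 1 to compound 3) and (a step that the two limits leave unreadable from compound 2 to compound 3) have no readable size, and neither alters the group on that oxygen. They therefore offer no guide to a direction. Compound 3 at < 1.6 ug/mL as a limit is the only anchor, so another limit is the likeliest report for compound 4. The expected step in this assay is (a step that the limit leaves unreadable from compound 3 to compound 4) with no shift beyond the usual scatter expected in either direction. The estimate for compound 4 is 1.5 ug/mL with 0.7 ug/mL to 6 ug/mL as its expected range.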

Compound 4, solubility: < 1.6 ug/mL
Compound 4: only a limit was reported; the forecaster's own chance of this, stated with the estimate: 75%; the middle value is on the limit's open side.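

In this assay compound 4 gives < 1.6 ug/mL, which is a limit and not a number. Compound 3 also gives only a limit, so no step can be read between compound 3 and compound 4. The compounds shown leave open whether 1-carboxy-1-methylethyl in place of carboxymethyl on an oxygen on an aromatic ring changes the reading at all.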